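The source may report more compounds than this note shows. Statements on the series, on what has been measured and on what is new or still open speak of the compounds shown alone.

Compound 2 `CC(C)c1ccc(CSc2ncnc3c2ncn3[C@@H]2O[C@H](CO)[C@@H](O)[C@H]2O)cc1` gives the lowest of the two numbers recorded so far in an assay on isolated protein for binding affinity to Equilibrative nucleoside transporter 1 (Homo sapiens) (on this read-out lower numbers stand for stronger inhibition and higher numbers for weaker inhibition), at 4790 nM. Compound 1 `CCSc1ncnc2c1ncn2[C@@H]1O[C@H](CO)[C@@H](O)[C@H]1O` gives 57500 nM in this assay. Within the data shown here, the one step measured, a 12-fold lower number from compound 1 to compound 2 (1.08 log units; beyond the scatter), is large. Compound 3 `Cc1cccc(CSc2ncnc3c2ncn3[C@@H]2O[C@H](CO)[C@@H](O)[C@H]2O)c1` differs from compound 2 by 3-methylphenyl in place of 4-isopropylphenyl on a saturated chain carbon bound to a sulfur. This keeps an aromatic ring at the same place, so a much smaller shift than that step is expected, probably toward a somewhat higher number. For compound 3 the expected value is 9000 nM (range 3000 nM to 27000 nM), an estimated step of a 1.9-fold higher number from compound 2 to compound 3 (0.27 log units; within the scatter).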

Compound 3, half-maximal inhibitory concentration: 12000 nM
For compound 3 the middle estimate is 1.3-fold (0.12 log units) below the measured one; low and high end bracket the measured number.
By their numbers in this assay, from the lowest: compound 2; then compound 3; then compound 1.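

Replacing 4-isopropylphenyl with 3-methylphenyl on a saturated chain carbon bound to a sulfur gives a 2.5-fold higher number from compound 2 to compound 3 (0.40 log units; beyond the scatter), so the identity of the aromatic group matters here, not just its presence. Compound 3 still improves on the methyl of compound 1, with a 4.8-fold lower number from compound 1 to compound 3 (0.68 log units; beyond the scatter), so two different aromatic groups now give lower numbers than the methyl. Nothing available explains these shifts.

Compound 3 alters both the size of the ring's substituent and where it sits, so their contributions remain unseparated. On these data alone, how an amine or a carboxylic acid on the ring would behave also remains open.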